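Cytotoxicity notes: triazole substituent change from compound 2 to compound 4

A few compounds are considered here, and "the series" means these few. Any claim that something is new, unique, unknown or untested is made for them only; others in the source may bear on it.

Measured so far:
compound 1 `O=C1O[C@H]([C@@H](O)Cn2cc(CNS(=O)(=O)c3ccc(Cl)cc3F)nn2)C(OCc2ccccc2)=C1OCc1ccccc1` — 20 nM
compound 2 `O=C1O[C@H]([C@@H](O)Cn2cc(CCO)nn2)C(OCc2ccccc2)=C1OCc1ccccc1` — 58500 nM
compound 3 `O=C1O[C@H]([C@@H](O)Cn2cc(-c3cc(C(F)(F)F)cc(C(F)(F)F)c3)nn2)C(OCc2ccccc2)=C1OCc1ccccc1` — 80700 nM

In an ADME assay on HFF cells (Homo sapiens) for cytotoxicity, read by MTT assay, with a stated time of 72 h (a lower number here means a stronger inhibitor, a higher number a weaker inhibitor), compound 2 gives 58500 nM, the second highest of the three numbers; compound 3 sits within the scatter of it, while compound 1 is far lower. Going by the values given here, the one measured step that touches compound 2 is a 2900-fold higher number from compound 1 to compound 2 (3.47 log units; beyond the scatter), with the ((4-chloro-2-fluorophenyl)sulfonyl)amino group leaving and hydroxymethyl entering on the saturated chain carbon bound to the aromatic carbon.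

Compound 4 `O=C1O[C@H]([C@@H](O)Cn2cc(-c3ccc(Br)cc3)nn2)C(OCc2ccccc2)=C1OCc1ccccc1` is not yet measured. The change is 4-bromophenyl in place of 2-hydroxyethyl on an aromatic carbon. Among the compounds with values here, no measured step covers this change directly. Compound 3 also carries an aryl group on the same aromatic carbon of the five-membered ring, and its value lies within the scatter of compound 2, so no pronounced step is expected in this assay here; the aryl-for-hydroxyethyl swap is not the sulfonamide change that made compound 1 stand apart. The estimate for compound 4 is therefore 55000 nM (range 15000 nM to 150000 nM), a step of a 1.1-fold lower number from compound 2 to compound 4 (0.03 log units; within the scatter) expected to fall within the scatter.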

Compound 4, half-maximal inhibitory concentration: 5100 nM
Estimate against measurement, compound 4: 11-fold (1.03 log units) above, outside the stated range (below it).
By their numbers in this assay, from the lowest: compound 1; then compound 4; then compounds 2 and 3 (each within the scatter of the next).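

In this assay the aromatic carbon of the five-membered ring responds to more than the sulfonamide change: 4-bromophenyl in place of 2-hydroxyethyl gives an 11-fold lower number from compound 2 to compound 4 (1.06 log units; beyond the scatter) and thus moves the number by a large step with no sulfonyl group present. An aryl group on this carbon does not settle the reading on its own, since compound 4 gives 5100 nM while compound 3, with its own aryl group on the same carbon, gives 80700 nM and the two differ in what the phenyl ring carries. Nothing at hand accounts for the step from 2-hydroxyethyl to 4-bromophenyl.

Going by these compounds, whether a plain phenyl or a 4-aminophenyl group on this carbon would read nearer compound 4 or compound 3 stays open. Also open, on these data alone, is whether a longer chain ending in a hydroxyl group would stay close to compound 2.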